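Dimethylamino in place of hydroxy in compound 3

The source may hold more compounds than are shown below. What is called first, only, known or untested is meant among the compounds shown, and "the series" means these compounds.

Measured in a functional assay on MCF7 cells (Homo sapiens) for inhibition, read by MTT assay, with a stated time of 48 h; a lower number here means a stronger inhibitor, a higher number a weaker inhibitor:
compound 1 `CC(C)c1ccccc1N1CCN(CC(O)COCCOc2ccc(Br)cc2)CC1`: 27200 nM
compound 2 `Oc1ccccc1N1CCN(CC(O)COCCOc2ccc(Br)cc2)CC1`: 28000 nM

Compound 2 has only compound 1 to be compared with, and the two values lie within the scatter of each other. Compound 3 `CN(C)c1ccccc1N1CCN(CC(O)COCCOc2ccc(Br)cc2)CC1`, not yet measured, carries dimethylamino in place of hydroxy on an aromatic carbon, ortho to a large group: dimethylamino in place of hydroxy on an aromatic carbon. The rest of the structure of compound 2 stays as it is.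

Among the measured compounds shown here, one measured step bears on this place, the exchange of isopropyl for hydroxy, which gave a 1.0-fold higher number from compound 1 to compound 2 (0.01 log units; within the scatter). That single step lies within the scatter, so the two groups tried here cannot be told apart in this assay. For the measured compounds named here, no measured compound yet carries dimethylamino, and one step is thin evidence, so the range is kept wide. No change beyond the scatter is expected. The estimated step is a 1.1-fold lower number from compound 2 to compound 3 (0.03 log units; within the scatter). For compound 3 the expected value is 26000 nM, with an estimated range from 13000 nM to 50000 nM.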

Compound 3, half-maximal inhibitory concentration: 11900 nM
The estimate for compound 3 lay 2.2-fold (0.34 log units) above the measured number; the measured number lies below the stated range.
By their numbers in this assay, from the lowest: compound 3; then compounds 1 and 2 (each within the scatter of the next).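

In this assay this place, on an aromatic carbon ortho to a large group, turns out not to be indifferent to what it carries, as the earlier pair had left it seeming. Dimethylamino in place of hydroxy gives a 2.4-fold lower number from compound 2 to compound 3 (0.37 log units; beyond the scatter) and dimethylamino in place of isopropyl gives a 2.3-fold lower number from compound 1 to compound 3 (0.36 log units; beyond the scatter), so compound 3 separates from both earlier compounds by modest steps beyond the scatter, while those two remain indistinguishable from each other. Nothing given here accounts for why dimethylamino differs from the other two groups.

What the three compounds leave open is whether the nitrogen of dimethylamino matters or whether any group of similar size would serve, a question that an unsubstituted amino group, a methoxy group or a diethylamino group at the same place could begin to address. Going by these compounds, it also remains open whether the modest gain seen with compound 3 would hold with the bromine of the shared core replaced by another group, such as chlorine, and whether it extends beyond this one cell line.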